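From thiazolyl amide to benzyl amide

A few compounds are considered here, and "the series" means these few. Any claim that something is new, unique, unknown or untested is made for them only; others in the source may bear on it.

In a functional assay on MCF7 cells (Homo sapiens) for inhibition, read by MTT assay, with a stated time of 72 h (a lower number here means a stronger inhibitor, a higher number a weaker inhibitor), compound 1 `CCCc1ccc(NC(=O)C2CCN(C/C=C/c3ccccc3)CC2)cc1` gives 9030 nM and compound 3 `O=C(Nc1nccs1)C1CCN(C/C=C/c2ccccc2)CC1` gives 28600 nM, the higher of the two numbers. Compound 2 `COc1ccccc1NC(=O)C1CCN(C/C=C/c2ccccc2)CC1` reads > 100000 nM, which is a limit of the assay. Compound 4 `O=C(NCc1ccccc1)C1CCN(C/C=C/c2ccccc2)CC1` differs from compound 3 by benzyl in place of 1,3-thiazol-2-yl on an amide-type nitrogen. Among the measured compounds shown here, no measured step makes this exact swap. The nearest swaps on that nitrogen are an at least 11-fold higher number from compound 1 to compound 2 (1.04 log units; beyond the scatter), a 3.2-fold higher number from compound 1 to compound 3 (0.50 log units; beyond the scatter) and an at least 3.4-fold lower number from compound 2 to compound 3 (0.54 log units; beyond the scatter). These run in both directions, so no direction is favoured, and only a small step is expected in this assay. The estimated change is a 1.0-fold higher number from compound 3 to compound 4 (0.02 log units; within the scatter). For compound 4 the expected value is 30000 nM, with an estimated range of 10000 nM to 100000 nM.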

Compound 4, half-maximal inhibitory concentration: > 100000 nM
Compound 4: a limit, no number; the forecaster's own chance of this, stated with the estimate: 20%; middle value at least 3.3-fold (0.52 log units) from the limit.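

In this assay, benzyl on the amide-type nitrogen gives an at least 3.4-fold higher number from compound 3 to compound 4 (0.54 log units; beyond the scatter) and an at least 11-fold higher number from compound 1 to compound 4 (1.04 log units; beyond the scatter), so neither amide with a readable number keeps it after this swap. Only 4-propylphenyl and 1,3-thiazol-2-yl on this nitrogen so far give a number, and a carbon-only aromatic ring alone does not secure one, as 4-propylphenyl and benzyl differ. Compound 4 is a limit, not a number, and the step from compound 2 cannot be read: the limit of > 100000 nM in this assay, at which 2 of the 4 values shown sit.

Going by these compounds, whether 2-phenylethyl or 4-propylbenzyl on that nitrogen would return a readable number stays open. On these data alone, how weak compound 2 and compound 4 really are also stays open.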